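Furan-2-yl to 4-methylphenyl: a step beside the assay limit

A few compounds are considered here, and "the series" means these few. Any claim that something is new, unique, unknown or untested is made for them only; others in the source may bear on it.

The study follows two measured compounds and one still to be measured in an assay on cells for inhibition of histone deacetylase 8 (Homo sapiens), read by fluorescence, with a stated time of 30 min; a higher number here means a weaker inhibitor, a lower number a stronger inhibitor. Compound 1 `O=C1NC(=O)/C(=C\c2ccc(OCC(=O)N3N=C(c4ccccc4)CC3c3ccc(F)cc3F)cc2)S1` gives 34000 nM in this assay. Compound 2 `O=C1NC(=O)/C(=C\c2ccc(OCC(=O)N3N=C(c4ccc(F)cc4)CC3c3ccco3)cc2)S1` returns only a limit in this assay, namely > 50000 nM. Among the compounds with values here, compound 2 thus stands at the limit of > 50000 nM in this assay, at which 1 of the 2 values shown sits, so the two measured values show only that compound 1 registered a number while compound 2 did not. Compound 3 `Cc1ccc(C2CC(c3ccc(F)cc3)=NN2C(=O)COc2ccc(/C=C3/SC(=O)NC3=O)cc2)cc1` differs from compound 2 in a single place: 4-methylphenyl in place of furan-2-yl on a saturated ring carbon. Within the data shown here, no measured pair differs at that position alone, so the size of this step has no precedent here. The step of an at least 1.1-fold lower number from compound 2 to compound 3 (0.04 log units; that floor lies within the scatter) is expected to be small, not beyond the usual scatter, with a fair chance that only a limit is reported again. Compound 3 is expected to give about 45000 nM in this assay, between 15000 nM and 150000 nM.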

Compound 3, half-maximal inhibitory concentration: > 50000 nM
Compound 3: no number, only a limit; the forecaster's own chance of this, stated with the estimate: 55%; at least 1.1-fold (0.04 log units) between middle value and limit.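

In this assay compound 3 returns only the limit > 50000 nM and no number. Compound 2 also returns only a limit, so no step can be read between compound 2 and compound 3. The compounds shown leave open what number either compound would give, and whether 4-methylphenyl in place of furan-2-yl moves the value at all.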